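The source may report more compounds than this note shows. Statements on the series, on what has been measured and on what is new or still open speak of the compounds shown alone.

Three related compounds have been measured in a functional assay on HL-60 cells (Homo sapiens) for inhibition, read by CCK-8 assay, with a stated time of 48 h; a lower number here means a stronger inhibitor, a higher number a weaker inhibitor. Compound 2 `O=C(NCCNS(=O)(=O)c1sccc1-c1ccccc1Oc1ccc(O)c(O)c1)Nc1cc(C(F)(F)F)cc(C(F)(F)F)c1` gives 5700 nM in this assay, and compound 1 `Cc1ccc(-c2ccsc2S(=O)(=O)NCCNC(=O)Nc2cc(C(F)(F)F)cc(C(F)(F)F)c2)c(Oc2ccc(O)c(O)c2)c1` gives 3700 nM in this assay. The difference between them is methyl in place of hydrogen on an aromatic carbon, and the step of a 1.5-fold lower number from compound 2 to compound 1 (0.19 log units; within the scatter) shows how little that change moved the number. Compound 3 `O=S(=O)(NCCNC(=S)Nc1cc(C(F)(F)F)cc(C(F)(F)F)c1)c1sccc1-c1ccccc1Oc1ccc(O)c(O)c1` gives 4300 nM in this assay; its value and that of compound 2 lie within the scatter of each other, and the difference between the two cores is not broken down here.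

Compound 4 `Cc1ccc(-c2ccsc2S(=O)(=O)NCCNC(=S)Nc2cc(C(F)(F)F)cc(C(F)(F)F)c2)c(Oc2ccc(O)c(O)c2)c1` has not yet been measured. It differs from compound 3 by methyl in place of hydrogen on an aromatic carbon, the same change that was made from compound 2 to compound 1, at the same place. Because the measured step of a 1.5-fold lower number from compound 2 to compound 1 (0.19 log units; within the scatter) stayed within the scatter, compound 4 is expected to end up close to compound 3. The expected step is a 1.3-fold lower number from compound 3 to compound 4 (0.13 log units; within the scatter) in this assay. The estimate for compound 4 in this assay is 3200 nM, expected to fall between 1500 nM and 7000 nM, resting on a single prior example of this change.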

Compound 4, half-maximal inhibitory concentration: 3200 nM
The estimate for compound 4 equals the measured number at the digits printed; low and high end bracket the measured number.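

In this assay methyl in place of hydrogen on an aromatic carbon gave a 1.3-fold lower number from compound 3 to compound 4 (0.13 log units; within the scatter) and, set beside the earlier pair, the change carried from one core to the other with no difference that can be told apart: the same change on two cores in this assay, a 1.5-fold lower number (0.19 log units; within the scatter) from compound 2 to compound 1 and a 1.3-fold lower number (0.13 log units; within the scatter) from compound 3 to compound 4, 1.1-fold (0.06 log units) apart, within the scatter of two such steps. Both pairs therefore agree, and in both the methyl leaves the number within the scatter. This does not show that the methyl has a real effect on either core, as steps this small cannot be told from repeat variation, and two pairs say nothing about how the change would behave on any further core in the series.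

What the compounds shown leave open is whether any other group at this place, meta to the 3,4-dihydroxyphenoxy group and para to a large group, would move the number beyond the scatter. An ethyl group, a longer chain, an amine or a carboxylic acid there would test this.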